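The source may hold more compounds than are shown below. What is called first, only, known or untested is meant among the compounds shown, and "the series" means these compounds.

Compound 1 `COc1cc(C)cc(-c2c(-c3ccnc(-c4ccc(C(C)=O)cc4)c3)cnn2CC#N)c1` gives 98% in a functional assay on Hs-578T cells (Homo sapiens) for cytotoxicity, read by sulforhodamine B assay, with a stated time of 48 h, tested at 0.01 uM; on this read-out lower numbers stand for a stronger effect and higher numbers for a weaker effect at the one concentration tested.
Compound 2 `Cc1cc(O)cc(-c2nn(CC#N)cc2-c2ccnc(-c3ccc(Oc4ccccc4)cc3)c2)c1` gives 91% in this assay.

The two numbers lie within the usual scatter of each other, so the two compounds stand together at the weak end of the effect, and compound 1 cannot be set apart from compound 2 on these numbers. Compound 3 `COc1cc(C)cc(-c2c(-c3ccnc(-c4ccc(N(C)C)cc4)c3)cnn2CC#N)c1` is not yet measured. It differs from compound 1 by dimethylamino in place of acetyl on an aromatic carbon. Among the measured compounds shown here, no measured pair shows such a change, so the step from compound 1 to compound 3 can only be expected to stay within the scatter, with an estimated a number 3 percentage points lower from compound 1 to compound 3 (within the scatter). Compound 3 is thus expected to give about 95%, within 82% to 105%.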

Compound 3, a percentage reported as activity, at one concentration (the size of the read-out at that concentration, not a potency): 58%
Estimate against measurement, compound 3: 37 percentage points above; measured number below the stated range.
By their numbers in this assay, from the lowest: compound 3; then compounds 2 and 1 (each within the scatter of the next).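

In this assay the exchange of acetyl for dimethylamino, para to a large group, gives a number 40 percentage points lower from compound 1 to compound 3 (beyond the scatter) and is the first change shown to move the read-out. This place on the six-membered aromatic ring of carbon only is therefore sensitive to the group it carries, even though both groups have the same heavy-atom count. Nothing shown here accounts for the step.

Going by these compounds, it remains open whether other groups at this place, such as a primary amine or a carboxylic acid, would move the read-out as well. The compounds also leave open whether the step holds at other concentrations.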